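A few compounds are considered here, and "the series" means these few. Any claim that something is new, unique, unknown or untested is made for them only; others in the source may bear on it.

Compound 1 `CCCC(=O)c1c(OC)c(Cl)c(OC)c(Cl)c1OC` gives 20800 nM in a functional assay on the whole organism (S2 cells, strain S2) for inhibition, with Drosophila as the target, read by a luciferase reporter, with stated times of 1.5 h and 8 h; on this read-out lower numbers stand for stronger inhibition and higher numbers for weaker inhibition.
Compound 2 `CCCCCC(=O)c1c(O)c(Cl)c(C)c(Cl)c1O` gives 3800 nM in this assay.
Compound 3 `CCCC(=O)c1c(O)c(Cl)c(O)c(Cl)c1O` gives 21500 nM in this assay.

Among these three numbers, compound 1 holds the second highest. Its nearest neighbour is compound 3, whose number lies within the usual scatter of compound 1, so the two cannot be told apart. Compound 2 stands furthest away, with a number that is clearly lower than that of compound 1, a difference beyond the scatter; compound 2 differs from compound 1 at several points at once, so no single cause can be read from it.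

Compound 4 `CCCCCC(=O)c1c(OC)c(Cl)c(OC)c(Cl)c1OC` is obtained from compound 1 by one change: ethyl in place of hydrogen on a saturated chain carbon, three bonds along the chain from a carbonyl carbon. For the measured compounds named here, no pair of measured compounds differs only in this way, so there is no measured step to lean on. The expectation for compound 4 is a small shift towards a lower number, of a size that may not clear the scatter, shown as a 2.1-fold lower number from compound 1 to compound 4 (0.32 log units; beyond the scatter). The estimate for compound 4 in this assay is 10000 nM, with a range from 3000 nM to 30000 nM.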

Compound 4, half-maximal inhibitory concentration: 18900 nM
Beside the measured number, compound 4's estimate is 1.9-fold (0.28 log units) below it; low and high end bracket the measured number.
By their numbers in this assay, from the lowest: compound 2; then compounds 4, 1 and 3 (each within the scatter of the next).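

For the compounds shown here, with a 1.1-fold lower number from compound 1 to compound 4 (0.04 log units; within the scatter) in this assay, this position now has its first direct reading, since the earlier compounds offered no pair differing only here. On the core of compound 1, ethyl in place of hydrogen on a saturated chain carbon, three bonds along the chain from a carbonyl carbon, leaves the number within the scatter, so the change from propyl to pentyl has no effect that can be told apart from repeat measurement. Nothing available explains why this change has so little effect.

Still open, on these data alone, is whether a longer chain such as octyl, or a chain ending in an amine or a carboxylic acid, would move the number at this position. Also open, as far as these compounds go, is whether propyl to pentyl would read the same on a different core.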